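From methoxy to nitro on a shared core

The source may report more compounds than this note shows. Statements on the series, on what has been measured and on what is new or still open speak of the compounds shown alone.

Within the data shown here, in a functional assay on NCI-H460 cells (Homo sapiens) for cytotoxicity (a higher number here means a weaker inhibitor, a lower number a stronger inhibitor), compound 1 (`COc1ccc2nc(NC(=O)CCCCC(=O)NO)sc2c1`) gives 21.4 ug/mL and stands highest of the two numbers known. Compound 3 (`O=C(CCCCC(=O)Nc1nc2ccc([N+](=O)[O-])cc2s1)NO`) keeps the chain of compound 1 and takes nitro in place of methoxy on an aromatic carbon. Among the measured compounds shown here, no measured pair shows this change alone. Compound 2 (`O=C(CCCCCCC(=O)Nc1nc2ccc([N+](=O)[O-])cc2s1)NO`) also carries nitro but has a longer chain, and compound 2 gives 1.9 ug/mL with both differences, so only part of that gap is expected in this assay as a move to a lower number. The expected step is a 2.7-fold lower number from compound 1 to compound 3 (0.43 log units; beyond the scatter) and no larger. Compound 3 is estimated at 8 ug/mL with 2.5 ug/mL to 25 ug/mL as its expected range.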

Compound 3, half-maximal inhibitory concentration: > 30 ug/mL
Compound 3 was reported as a limit; the forecaster's own chance of this, stated with the estimate: 3%; middle value at least 3.7-fold (0.57 log units) away from the limit.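

In this assay compound 3 gives > 30 ug/mL, a limit of the assay and not a number. On the shorter chain, nitro in place of methoxy on an aromatic carbon brings no move to a lower number, only an at least 1.4-fold higher number from compound 1 to compound 3 (0.14 log units; that floor lies within the scatter). With nitro kept, hydroxycarbamoyl in place of 2-(hydroxycarbamoyl)ethyl gives an at least 15-fold higher number from compound 2 to compound 3 (1.19 log units; beyond the scatter), so the low number of compound 2 goes with its longer chain.

From the compounds shown here alone, the full size of both steps stays unread because compound 3 is known only as a limit: the limit of > 30 ug/mL in this assay, at which 1 of the 3 values shown sits. Whether an amine or a chlorine at this aromatic carbon would give a lower number, and what methoxy does on the longer chain, stay open.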